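This account rests on a few compounds, and the source may have more. Where it says the series, first, only, none or still open, it means among the compounds named here.

Compound 1 `COc1cc(C(=O)NS(=O)(=O)c2cccs2)ccc1Cn1ccc2ccc(NC(=O)CC3CCCC3)cc21` gives 9.6 in a functional assay (trachea) for antagonist activity, with Cavia porcellus as the target; a lower number here means a less potent compound, a higher number a more potent compound, by a factor of ten per unit of this negative logarithm.
Compound 2 `COc1cc(C(=O)NS(=O)(=O)c2ccccc2Cl)ccc1Cn1ccc2ccc(NC(=O)CC3CCCC3)cc21` gives 9.8.
Compound 3 `COc1cc(C(=O)NS(=O)(=O)c2c(C)cccc2Cl)ccc1Cn1ccc2ccc(NC(=O)CC3CCCC3)cc21` gives 8.8.

Compound 3 stands lowest of the three in this assay; both steps down to it lie beyond the scatter. Compound 4 `COc1cc(C(=O)NS(=O)(=O)c2ccc3ccccc3c2)ccc1Cn1ccc2ccc(NC(=O)CC3CCCC3)cc21` differs from compound 3 by naphthalen-2-yl in place of 2-chloro-6-methylphenyl on a sulfonyl sulfur. Among the measured compounds shown here, three measured steps bear on the group on the sulfonyl sulfur: a number 0.20 log units higher from compound 1 to compound 2 (within the scatter), a number 0.80 log units lower from compound 1 to compound 3 (beyond the scatter) and a number 1.00 log units lower from compound 2 to compound 3 (beyond the scatter). The two aryl groups without the methyl sat higher than the 2-chloro-6-methylphenyl, so its departure for another aromatic group is expected to raise the number beyond the scatter in this assay, roughly back to the level of the first two compounds. The expected step is a number 0.60 log units higher from compound 3 to compound 4 (beyond the scatter). Compound 4 is thus estimated at 9.4, with a range from 8.7 to 10.1.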

Compound 4, negative logarithm of the antagonist equilibrium constant: 8.3
The estimate for compound 4 lay 1.10 log units above the measured number, and the stated range ends above it.
By their numbers in this assay, from the lowest: compound 4; then compound 3; then compounds 1 and 2 (each within the scatter of the next).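

In this assay, naphthalen-2-yl on the sulfonyl sulfur gives the lowest number of the four compounds: a number 0.50 log units lower from compound 3 to compound 4 (beyond the scatter), a number 1.50 log units lower from compound 2 to compound 4 (beyond the scatter) and a number 1.30 log units lower from compound 1 to compound 4 (beyond the scatter). An aromatic group at this place therefore does not by itself keep the number at the level of compound 1 and compound 2, and the larger, two-ringed group falls even below the 2-chloro-6-methylphenyl of compound 3. Nothing available explains this drop. The compounds shown leave open how an unsubstituted phenyl, a naphthalen-1-yl or a saturated cyclohexyl on this sulfur would read.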